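The source may report more compounds than this note shows. Statements on the series, on what has been measured and on what is new or still open speak of the compounds shown alone.

Measured so far in an assay on isolated protein for inhibition of leukotriene B4 receptor 1 (Homo sapiens), tested at 10 uM; on this read-out lower numbers stand for less inhibition and higher numbers for more inhibition at the one concentration tested (going by the name of the read-out):
compound 1 `C=CCc1cc(C(C)=O)c(O)cc1OCCCCC` gives 60%
compound 2 `C=CCc1cc(C(C)=O)c(O)cc1OCc1ccc(C#N)cc1` gives 22%
compound 3 `CCc1cc(C(C)=O)c(O)cc1OCc1ccc(C#N)cc1` gives 7%

Compound 3 holds the lowest of the three numbers in this assay; compound 2 stands nearest to it and compound 1 furthest, both beyond the scatter. Among the compounds with values here, only one step is defined within the set, a number 15 percentage points lower from compound 2 to compound 3 (beyond the scatter), a modest drop that goes with methyl in place of vinyl on a saturated chain carbon bound to an aromatic carbon. Within the data shown here, compound 1 and compound 2 differ in more than one place and no step is defined for them; their values show only that compound 1 sits clearly higher.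

Compound 4 `CCc1cc(C(C)=O)c(O)cc1OCc1ccc(C(=O)O)cc1` is the unmeasured member. Its difference from compound 3 is carboxy in place of cyano on an aromatic carbon. Among the measured compounds shown here, no measured step touches this kind of change: the one defined step alters the chain bound to the aromatic carbon, not the group on the six-membered aromatic ring. The expectation therefore rests on compound 3 alone, and the step is expected to be a number 8 percentage points higher from compound 3 to compound 4 (within the scatter), not beyond the scatter, with a range widened for the lack of any precedent. Compound 4 is estimated at 15%, between 0% and 40%.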

Compound 4, a percentage reported as inhibition, at one concentration (the size of the read-out at that concentration, not a potency): 22%
For compound 4 the middle estimate is 7 percentage points below the measured one; low and high end bracket the measured number.
By their numbers in this assay, from the lowest: compound 3; then compounds 2 and 4 (each within the scatter of the next); then compound 1.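

In this assay, within the data shown here, the group on the aromatic carbon para to a large group proves able to move the read-out: carboxy in place of cyano gives a number 15 percentage points higher from compound 3 to compound 4 (beyond the scatter), the only step at this position. The series therefore now holds a step at this ring position as well as the earlier one on the chain bound to an aromatic carbon, and the new step rises where the earlier one fell. Carboxy brings a hydrogen-bond donor that cyano lacks, as well as more heavy atoms, but this single step cannot separate these differences, and no measurement at hand explains the rise.

Open, as far as these compounds go, is whether an amide, a methyl ester or a hydroxymethyl group at the same position would read like carboxy or like cyano, which would show how much of the carboxy group the step depends on. Also open is whether carboxy in place of cyano gives a similar step when the chain of compound 2 is present on the core, since the compounds shown hold this change in only one pair.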